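A few compounds are considered here, and "the series" means these few. Any claim that something is new, unique, unknown or untested is made for them only; others in the source may bear on it.

Measured compounds:
compound 1, `O=C(O)C1CC1c1ccc(NCc2cccc(Oc3ccccc3)c2)cc1`, gives 74%
compound 2, `O=C(O)CCc1cccc(NCc2cccc(Oc3ccccc3)c2)c1`, gives 148%

Both compounds share a core that carries an acid-bearing arm on a benzene ring. They were tested in a functional assay on CHO cells for agonist activity at Free fatty acid receptor 1 (Homo sapiens), read by reporter gene assay; a lower number here means a smaller maximal response, a higher number a larger maximal response. Compound 1 stands lowest of the two numbers; its nearest neighbour is compound 2, which lies higher by a margin beyond the usual scatter of repeated measurements.

Compound 3, `O=C(O)CCCc1ccc(NCc2cccc(Oc3ccccc3)c2)cc1`, has not yet been measured. It differs from compound 1 in one place: 3-carboxypropyl in place of 2-carboxycyclopropyl on an aromatic carbon. The acid group is kept, but the three-membered ring is opened into a chain of the same atom count.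

Going by the values given here, no pair of measured compounds differs in exactly this way, so the size of the step is uncertain. A moderate rise in this assay seems plausible, because compound 2, whose acid also sits on a chain with no ring, gives 148%, while compound 1 gives 74%. The step from compound 1 to compound 3 is expected to be a number 26 percentage points higher from compound 1 to compound 3 (beyond the scatter). Compound 3 is therefore estimated to reach 100%, within a range from 60% to 145%.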

Compound 3, largest response reached (reported as percent of maximum), in percent of the reference or control that the assay uses: 74%
Estimate against measurement, compound 3: 26 percentage points above, within the range that was stated.
By their numbers in this assay, from the lowest: compounds 1 and 3 (each within the scatter of the next); then compound 2.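

In this assay, opening the three-membered ring of 2-carboxycyclopropyl into the open chain of 3-carboxypropyl gives no change at the digits printed from compound 1 to compound 3 (within the scatter). The earlier compounds shown here offered no direct test of this change, and this pair shows that, on this aromatic carbon para to a large group, an arm with the ring and an arm without it are not told apart by the largest response reached, at least when the acid is kept and the heavy-atom count stays the same. No measurement shown here offers a reason for this result, so it stands as an observation without an explanation.

Going by these compounds, the two arms compared here have the same size, so it remains open whether a longer chain ending in the carboxylic acid, such as 4-carboxybutyl, would also leave the response unchanged at this position. On these data alone, it is equally open what would happen if an amine took the place of the carboxylic acid on the 3-carboxypropyl arm, a change that would test how much this read-out depends on the acid itself.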